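Hydroxy to methoxy on compound 2

This account rests on a few compounds, and the source may have more. Where it says the series, first, only, none or still open, it means among the compounds named here.

Compound 1 `CC1(C)C=Cc2c(ccc(C(=O)/C=C/c3cnc4ccccc4c3)c2O)O1` gives "not determined" (no result reported)
Compound 2 `CC(C)=CCC/C(C)=C/COc1ccc(C(=O)/C=C/c2ccc(O)cc2)cc1` gives 12900 nM

For the measured compounds named here, in an ADME assay on Vero cells (Chlorocebus sabaeus) for cytotoxicity, read by MTT assay, with a stated time of 72 h (on this read-out lower numbers stand for higher toxicity in this test and higher numbers for lower toxicity in this test), compound 2 at 12900 nM holds the only number so far; compound 1 has no reported result. Compound 3 `COc1ccc(/C=C/C(=O)c2ccc(OC/C=C(\C)CCC=C(C)C)cc2)cc1` alters compound 2 in one place: methyl in place of hydrogen on an oxygen on an aromatic ring puts methyl in place of hydrogen on an oxygen on an aromatic ring, turning 4-hydroxyphenyl into 4-methoxyphenyl. Going by the values given here, no measured pair shows this change, so with compound 2 at 12900 nM as the sole anchor, no step beyond the usual scatter is expected in this assay in either direction. The expected 1.2-fold higher number from compound 2 to compound 3 (0.07 log units; within the scatter) is estimated to be small. For compound 3 the estimate is 15000 nM with an expected range of 6000 nM to 40000 nM in this test.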

Compound 3, half-maximal cytotoxic concentration: 147000 nM
Estimate against measurement, compound 3: 9.8-fold (0.99 log units) below; measured number outside the range, above it.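

In this assay, putting methyl in place of hydrogen on an oxygen on an aromatic ring brings an 11-fold higher number from compound 2 to compound 3 (1.06 log units; beyond the scatter) as 4-hydroxyphenyl becomes 4-methoxyphenyl. This first measured step shows that this position is not silent: one added carbon moves the read-out well beyond the scatter, towards lower toxicity in this test. Nothing shown gives a reason for this rise.

Still open, going by these compounds, is whether an ethyl group or a longer chain on this oxygen, or an amine in place of the hydroxy, would shift the number further or in the opposite direction. One pair also cannot show whether the same change acts alike on another core.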